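Naphthalen-1-yl in place of 3-chlorophenyl on the core

The compounds below may be only part of what the source reports. "The series", "measured", "known", "first", "only" and "open" are said of these compounds alone.

Compound 1: `Cn1cncc1C(OCc1ccc(C#N)cc1-c1cccc(Cl)c1)c1ccc(C#N)nc1`, 2.1 nM
Compound 2: `CN1CCN(c2nc(COC(c3ccc(C#N)cc3)c3cncn3C)c(-c3cccc(Cl)c3)cc2C#N)CC1`, 2 nM

Of the compounds shown here, two have been measured in a functional assay on NIH3T3 cells (Mus musculus); a higher number here means that more compound is needed for the effect, a lower number that less compound is needed. Compound 1 gives 2.1 nM, which is the higher of the two numbers, and compound 2 gives 2 nM; the gap between them lies within the usual scatter of repeated measurements, so the two values show no difference that can be read as a change. Among the compounds with values here, no step between measured compounds that differ in one place is available.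

The account follows compound 1 to compound 3, `Cn1cncc1C(OCc1ccc(C#N)cc1-c1cccc2ccccc12)c1ccc(C#N)nc1`, which has not yet been measured in this assay. The change is naphthalen-1-yl in place of 3-chlorophenyl on an aromatic carbon. It sits on an aromatic carbon of a six-membered aromatic ring of carbon only, ortho to a large group and meta to a cyano group, and nothing measured here speaks to a change at that place.

For compound 3 the expectation is a modest rise in the number, of about a 1.9-fold higher number from compound 1 to compound 3 (0.28 log units; within the scatter), which is only a guess with a wide range. The estimated value for compound 3 in this assay is 4 nM, between 1 nM and 16 nM.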

Compound 3, half-maximal effective concentration: 46 nM
Compound 3: the middle estimate sits 12-fold (1.06 log units) below what was measured, and the stated range ends below it.
By their numbers in this assay, from the lowest: compounds 2 and 1 (each within the scatter of the next); then compound 3.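

At this position, on an aromatic carbon ortho to a large group and meta to a cyano group, the aryl group cannot be exchanged freely in this assay: naphthalen-1-yl in place of 3-chlorophenyl gives a 22-fold higher number from compound 1 to compound 3 (1.34 log units; beyond the scatter). Within the data shown here, this is the first step read at this place, and it shows that the number there responds strongly to the identity of the aryl group, which compounds 1 and 2 alone could not show. The change removes the chlorine and adds a second six-membered aromatic ring of carbon only in one move, so the step cannot say which of the two matters, and no measurement shown here accounts for its size.

From the compounds shown here alone, whether a plain phenyl, a 3-methoxyphenyl or a pyridin-3-yl group at this place would stay close to compound 1 at 2.1 nM or move toward compound 3 at 46 nM remains open. Going by these compounds, it is equally open whether the same exchange would raise the number as far on compound 2, which carries further groups on its core.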